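Methoxy in place of methyl: notes on compound 3

This account rests on a few compounds, and the source may have more. Where it says the series, first, only, none or still open, it means among the compounds named here.

compound 1 `O=S(=O)(NCCCNc1nccc(-c2[nH]c(-c3ccccc3)nc2-c2ccc(F)c(O)c2)n1)c1ccc(Cl)cc1` gives 14200 nM in the first test
compound 2 `Cc1ccc(S(=O)(=O)NCCCNc2nccc(-c3[nH]c(-c4ccccc4)nc3-c3ccc(F)c(O)c3)n2)cc1` gives 26300 nM in the same test

Both values come from a functional assay on LOX IMVI cells (Homo sapiens) for cytotoxicity, read by MTT assay, with a stated time of 24 h (on this read-out lower numbers stand for stronger inhibition and higher numbers for weaker inhibition), and only these two numbers exist so far. Compound 2 at 26300 nM stands within the scatter of compound 1 at 14200 nM so the pair carries no order. Next comes compound 3 `COc1ccc(S(=O)(=O)NCCCNc2nccc(-c3[nH]c(-c4ccccc4)nc3-c3ccc(F)c(O)c3)n2)cc1` with methoxy in place of methyl on an aromatic carbon, para to a large group, counted as methoxy in place of methyl on an aromatic carbon with the shared core unchanged. Within the data shown here, one measured step bears on this place: a 1.9-fold higher number from compound 1 to compound 2 (0.27 log units; within the scatter) for methyl in place of chloro on an aromatic carbon, and it stayed within the scatter. Among the measured compounds shown here, that is a single step, and no measured compound yet carries methoxy. For the measured compounds named here, with it as the only guide, no shift beyond the scatter is expected in this assay and no direction is favoured. The expected step is a 1.2-fold lower number from compound 2 to compound 3 (0.08 log units; within the scatter) as an estimate only. For compound 3 the estimated value is 22000 nM with an expected range from 10000 nM to 45000 nM until a measurement is in hand.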

Compound 3, half-maximal inhibitory concentration: 13900 nM
For compound 3 the middle estimate is 1.6-fold (0.20 log units) above the measured one; measured number inside the range.
By their numbers in this assay, from the lowest: compounds 3, 1 and 2 (each within the scatter of the next).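

In this assay, methoxy on this aromatic carbon, para to a large group, gives a 1.9-fold lower number from compound 2 to compound 3 (0.28 log units; within the scatter) against methyl and a 1.0-fold lower number from compound 1 to compound 3 (0.01 log units; within the scatter) against chloro. The position now carries three different groups, and the 4-chlorophenyl, 4-methylphenyl and 4-methoxyphenyl members of the series stand within the scatter of one another, so the values give them no order. Adding an oxygen that counts as one hydrogen-bond acceptor therefore moves the number by no more than the scatter here, which the single chloro-to-methyl step could not show, and no accompanying measurement offers an explanation for this.

From the compounds shown here alone, whether this flat picture holds for a group of another kind at the same carbon, such as an amine, a carboxylic acid or a longer alkoxy chain, remains open. Going by these compounds, all three compounds also share the same core and sit in the same weak range of this one cell test, so it is equally open whether any change at this place can produce a step beyond the scatter.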